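Trimming a Methoxy Group: Compound 3 to Compound 4

A few compounds are considered here, and "the series" means these few. Any claim that something is new, unique, unknown or untested is made for them only; others in the source may bear on it.

The compounds were compared in a functional assay on SK-BR-3 cells (Homo sapiens) for antiproliferative activity; a higher number here means a weaker inhibitor, a lower number a stronger inhibitor. Compound 2 `COc1ccc(Cc2ccc3cc(NC(=O)c4ccc(O)c(CC=C(C)C)c4)c(=O)oc3c2C)cc1OC` reaches only a limit of the assay in this assay, namely > 100000 nM. Compound 1 `COc1cccc(Cc2ccc3cc(NC(=O)c4ccc(O)c(CC=C(C)C)c4)c(=O)oc3c2C)c1` gives 14800 nM in this assay. The change from compound 2 to compound 1 is hydrogen in place of methoxy on an aromatic carbon, and it brought an at least 6.7-fold lower number from compound 2 to compound 1 (0.82 log units; beyond the scatter). How much of that step is real is uncertain because of the limit of > 100000 nM in this assay, at which 1 of the 3 values shown sits. Compound 3 `COCOc1ccc(Cc2ccc3cc(NC(=O)c4ccc(OC(C)=O)c(CC=C(C)C)c4)c(=O)oc3c2C)cc1OC` gives 14200 nM in this assay, a number that stands within the scatter of compound 1; the difference between the cores of compound 3 and compound 2 is not broken down here.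

Compound 4 `COCOc1ccc(Cc2ccc3cc(NC(=O)c4ccc(OC(C)=O)c(CC=C(C)C)c4)c(=O)oc3c2C)cc1` has not yet been measured. The change from compound 3 to compound 4 is hydrogen in place of methoxy on an aromatic carbon. The two places are not the same word for word: in compound 2 the departing methoxy stood ortho to a methoxy group and para to a large group, whereas in compound 3 it stands ortho to a methoxymethoxy group and meta to a large group, so this is the same kind of change rather than the same one. Since the earlier step from compound 2 to compound 1 was an at least 6.7-fold lower number from compound 2 to compound 1 (0.82 log units; beyond the scatter), compound 4 is expected to give a lower number than compound 3, estimated as a 2.4-fold lower number from compound 3 to compound 4 (0.37 log units; beyond the scatter). For compound 4 the estimated value in this assay is 6000 nM, with a range from 2000 nM to 20000 nM.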

Compound 4, half-maximal inhibitory concentration: 13500 nM
For compound 4 the middle estimate is 2.3-fold (0.35 log units) below the measured one; the measured number falls inside the stated range.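

In this assay, going from the 3-methoxy-4-(methoxymethoxy)phenyl group to the 4-(methoxymethoxy)phenyl group gave a 1.1-fold lower number from compound 3 to compound 4 (0.02 log units; within the scatter), so on this core hydrogen in place of methoxy left the number within the scatter. The same change therefore did not carry over in size from one core to the other: the same change on two cores in this assay, an at least 6.7-fold lower number (0.82 log units; beyond the scatter) from compound 2 to compound 1 and a 1.1-fold lower number (0.02 log units; within the scatter) from compound 3 to compound 4, at least 6.4-fold (0.80 log units) apart, beyond the scatter of two such steps. These four compounds do not show which of the differences between the two cores goes with that gap, and the gap has no upper end, because one of the two steps rests on a limit of the assay: the limit of > 100000 nM in this assay, at which 1 of the 4 values shown sits.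

The compounds shown leave open whether the gap goes with the methoxymethoxy group or with the acetoxy group, both of which compound 3 and compound 4 carry and neither of which compound 1 or compound 2 carries. They also leave open how either core would respond to a different group at the same place, such as an amine or a chlorine atom in place of the methoxy group.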